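The source may report more compounds than this note shows. Statements on the series, on what has been measured and on what is new or still open speak of the compounds shown alone.

In a functional assay on Caco-2 cells (Homo sapiens) for cytotoxicity, read by MTT assay, with stated times of 6 h and 48 h (on this read-out lower numbers stand for stronger inhibition and higher numbers for weaker inhibition), compound 1 `COc1ccc(OC)c(C(=O)/C=C/c2cc(Br)c(Br)n2C)c1` gives >= 100000 nM, which is a limit of the assay and not a number. Compound 3 `Cn1c(/C=C/C(=O)c2cccc(N)c2)cc(Br)c1Br` gives >= 100000 nM, which is also a limit. Compound 2 `Cn1c(/C=C/C(=O)c2ccc(O)cc2)cc(Br)c1Br` gives a true number, 6000 nM. Compound 1 therefore has no exact position on the scale: the limit of >= 100000 nM in this assay, at which 2 of the 3 values shown sit. Compound 4 `COc1ccc(OC)c(C(=O)/C=C/c2cc(Br)c(Br)[nH]2)c1` differs from compound 1 in one place, with hydrogen in place of methyl on an aromatic nitrogen. For the measured compounds named here, no measured pair shows this change, so only a modest move towards stronger inhibition is expected in this assay. The estimate implies an at least 2.0-fold lower number from compound 1 to compound 4 (0.30 log units; that floor lies within the scatter). For compound 4 the expected value is 50000 nM, with an estimated range from 10000 nM to 100000 nM.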

Compound 4, half-maximal inhibitory concentration: >= 100000 nM
Compound 4: only a limit was reported (the forecaster's own chance of this, stated with the estimate: 50%); middle value at least 2.0-fold (0.30 log units) away from the limit.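

Compound 1 and compound 4 both give only a limit, so no step between them can be read: the limit of >= 100000 nM in this assay, at which 3 of the 4 values shown sit.

The compounds shown leave open whether hydrogen in place of methyl on an aromatic nitrogen changes the result in this assay at all.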